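Swapping one bicyclic heteroaromatic ring for another

The compounds below may be only part of what the source reports. "The series", "measured", "known", "first", "only" and "open" are said of these compounds alone.

Compound 1 `O=C(NCc1ccc(S(=O)(=O)N2CCCCC2)cc1)c1cc2cnccc2s1` is one of three compounds tested in a functional assay on A2780 cells (Homo sapiens) for inhibition, read by sulforhodamine B assay, with a stated time of 72 h; on this read-out lower numbers stand for stronger inhibition and higher numbers for weaker inhibition. In this assay compound 1 gives 1600 nM, the highest of the two numbers recorded. Compound 2 `O=C(NCc1ccc(S(=O)(=O)c2ccccc2C(F)(F)F)cc1)c1cc2cnccc2[nH]1`, which carries a different bicyclic ring on the carbonyl and a different sulfonyl substituent, gives 25 nM, a far lower number that lies well beyond the usual scatter. Compound 3 `O=C(NCc1ccc(S(=O)(=O)c2ccccc2)cc1)c1cc(-c2cccnc2)no1` reaches only the limit of the assay, > 10000 nM, so no number is available for it; this is the point described by the limit of > 10000 nM in this assay, at which 1 of the 3 values shown sits.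

The step considered here leads from compound 1 to compound 4 `O=C(NCc1ccc(S(=O)(=O)N2CCCCC2)cc1)c1cc2ccncc2o1`. The two structures differ in one place: a group of 9 heavy atoms (7 carbon, 1 nitrogen, 1 oxygen; one five-membered aromatic ring with 1 hetero atom, one six-membered aromatic ring with 1 hetero atom) in place of a group of 9 heavy atoms (7 carbon, 1 nitrogen, 1 sulfur; one five-membered aromatic ring with 1 hetero atom, one six-membered aromatic ring with 1 hetero atom), on a carbonyl carbon. Within the data shown here, the ring sizes, counts of heavy atoms and hydrogen-bond acceptors stay the same, and no measured pair in this set isolates such an exchange, so no step can be read off directly. The change is expected to move the number little, within or only just beyond the scatter, with no firm direction; the estimated step from compound 1 to compound 4 is a 1.4-fold higher number from compound 1 to compound 4 (0.14 log units; within the scatter). For compound 4 the expected value in this assay is 2200 nM, in a range from 700 nM to 7000 nM.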

Compound 4, half-maximal inhibitory concentration: 29 nM
Estimate against measurement, compound 4: 76-fold (1.88 log units) above, outside the stated range (below it).
By their numbers in this assay, from the lowest: compounds 2 and 4 (each within the scatter of the next); then compound 1. At a limit, above all of these: compound 3.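

In this assay, the bicyclic group on the carbonyl carbon turns out to matter a great deal: exchanging it gives a 55-fold lower number from compound 1 to compound 4 (1.74 log units; beyond the scatter) with the rest of the molecule unchanged. This is the first pair shown that differs in one place, and so the first direct sign that this position responds strongly, even though the two groups match in ring sizes and in their counts of heavy atoms and hydrogen-bond acceptors. Nothing measured here accounts for the size of the step.

Only one such exchange is shown, so it remains open whether a bicyclic group with a plain benzene ring as its six-membered ring would give a similar number. Going by these compounds, it also remains open whether the same exchange gives a similar step when the sulfonyl carries another substituent, such as a longer alkyl chain or a carboxylic acid.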